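Triazolylmethylpyrrolidines at the sigma-2 site: a third aryl variant

The compounds below may be only part of what the source reports. "The series", "measured", "known", "first", "only" and "open" are said of these compounds alone.

Measured compounds:
- Compound 1 `Cn1nc(CN2CCCC2)nc1-c1ccc2ccsc2c1` — in an assay on membranes from Jurkat cells for displacement of a labelled ligand from Sigma intracellular receptor 2 (Homo sapiens), read by scintillation counting, with a stated time of 1 h (a lower number here means a stronger inhibitor, a higher number a weaker inhibitor), compound 1 gives only a limit, > 1000 nM.
- Compound 2 `Cn1nc(CN2CCCC2)nc1-c1cccc(Oc2ccccc2)c1` — in this assay compound 2 likewise gives only a limit, > 1000 nM.
- Compound 3 `CC(C)(C)c1ccc(-c2nc(CN3CCCC3)nn2C2CC2)cc1` — in this assay compound 3 gives 750 nM.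

Compound 2 therefore stands at the limit of > 1000 nM in this assay, at which 2 of the 3 values shown sit, so its value is not a number but a floor of the assay. For the measured compounds named here, no pair among the three is a single-point step, so no measured step size is available. Compound 4 `Cn1nc(CN2CCCC2)nc1-c1cccc(C2(C(F)(F)F)CC2)c1` is the next variant: 1-(trifluoromethyl)cyclopropyl in place of phenoxy on an aromatic carbon. With compound 2 at a limit, the direction cannot be read from the data; the expected step from compound 2 to compound 4 is a step that the limit leaves unreadable from compound 2 to compound 4, an estimate rather than a measured change. Compound 4 is estimated at 1300 nM, with a range from 400 nM to 4500 nM.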

Compound 4, inhibition constant: > 1000 nM
Compound 4: a limit, no number (the forecaster's own chance of this, stated with the estimate: 50%); the middle value does not contradict the limit.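

Compound 2 and compound 4 both give only a limit, so no step between them can be read: the limit of > 1000 nM in this assay, at which 3 of the 4 values shown sit.

Going by these compounds, how 1-(trifluoromethyl)cyclopropyl in place of phenoxy on an aromatic carbon changes the inhibition constant remains open.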